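The source may report more compounds than this note shows. Statements on the series, on what has been measured and on what is new or still open speak of the compounds shown alone.

Three compounds share one core, and they differ only in the group on the carbonyl carbon of the amide. Compound 1 `O=C(Nc1nnc(-c2cccc(O)c2O)s1)C1CCCCC1` carries a cyclohexyl there, and in a functional assay, with a stated time of 30 min, in the absence of a further agent (a lower number here means a stronger inhibitor, a higher number a weaker inhibitor), compound 1 gives 19900 nM. Compound 2 `O=C(COc1ccccc1)Nc1nnc(-c2cccc(O)c2O)s1` carries a phenoxymethyl, and compound 2 gives 16600 nM; the step of a 1.2-fold lower number from compound 1 to compound 2 (0.08 log units; within the scatter) is within the scatter. Compound 3 `CC(=O)Nc1nnc(-c2cccc(O)c2O)s1` carries a methyl, and compound 3 gives 111000 nM, the highest of the three numbers, beyond the scatter from both others.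

Compound 4 `Cc1ccc(C(=O)Nc2nnc(-c3cccc(O)c3O)s2)cc1` is the next step from compound 3: 4-methylphenyl in place of methyl on a carbonyl carbon. Within the data shown here, the steps that bear on this are a 5.6-fold higher number from compound 1 to compound 3 (0.75 log units; beyond the scatter) and a 6.7-fold higher number from compound 2 to compound 3 (0.83 log units; beyond the scatter), both in which the methyl stood against a larger group on the carbonyl carbon, and both in the same direction. Compound 4 goes the other way, from methyl to a larger group, so a step of similar size downward is expected, putting compound 4 near compound 1 and compound 2 rather than near compound 3. Among the measured compounds shown here, no measured step tells whether an aromatic ring bound directly to the carbonyl carbon behaves like the cyclohexyl or the phenoxymethyl, so the range is kept wide. The expected step is a 5.6-fold lower number from compound 3 to compound 4 (0.74 log units; beyond the scatter). For compound 4 the estimate is 20000 nM, with a range from 6000 nM to 60000 nM.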

Compound 4, half-maximal inhibitory concentration: 27100 nM
Beside the measured number, compound 4's estimate is 1.4-fold (0.13 log units) below it; the measured number falls inside the stated range.
By their numbers in this assay, from the lowest: compounds 2, 1 and 4 (each within the scatter of the next); then compound 3.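

In this assay, the step of a 4.1-fold lower number from compound 3 to compound 4 (0.61 log units; beyond the scatter) shows that a group with an aromatic ring bound directly to the carbonyl carbon, here 4-methylphenyl, also stands apart from the methyl, so that gap is not confined to the cyclohexyl and the phenoxymethyl. The 4-methylphenyl cannot be told apart from either of those groups, with a 1.6-fold higher number from compound 2 to compound 4 (0.21 log units; within the scatter) and a 1.4-fold higher number from compound 1 to compound 4 (0.13 log units; within the scatter), so the three larger groups form one level in these numbers despite their different shapes of attachment, and compound 3 alone lies apart from them. Nothing available here offers a reason for the gap that separates the methyl from the larger groups.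

The compounds shown leave open whether the methyl on the 4-methylphenyl contributes anything, which a plain phenyl would test, and how an ethyl or propyl chain on the carbonyl carbon would compare with the methyl and the larger groups. They also leave open whether a carboxylic acid or an amine on the aromatic ring would keep the number at this level or move it.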